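Benzyl in place of 4-methoxyphenyl: working notes on the series

A few compounds are considered here, and "the series" means these few. Any claim that something is new, unique, unknown or untested is made for them only; others in the source may bear on it.

Values in a functional assay on T98G cells (Homo sapiens) for inhibition, read by MTT assay, with a stated time of 72 h; on this read-out higher numbers stand for weaker inhibition and lower numbers for stronger inhibition
- compound 1 `CC1(C)CC(NC(=O)Nc2cccc(Cl)c2)c2cc(Br)ccc2O1` gives 67000 nM
- compound 2 `COc1ccc(NC(=S)NC2CC(C)(C)Oc3ccc(Br)cc32)cc1` gives 33000 nM
- compound 3 `CC1(C)CC(NC(=S)Nc2ccc([N+](=O)[O-])cc2)c2cc(Br)ccc2O1` gives 5000 nM

Compound 2 at 33000 nM holds the middle place of the three, with a higher number for compound 1 and a lower number for compound 3. The unmeasured compound 4 `CC1(C)CC(NC(=S)NCc2ccccc2)c2cc(Br)ccc2O1` differs from compound 2 in one place: benzyl in place of 4-methoxyphenyl on an amide-type nitrogen.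

One measured step starts from compound 2: a 6.6-fold lower number from compound 2 to compound 3 (0.82 log units; beyond the scatter). This modest step, nitro in place of methoxy on an aromatic carbon, bears only indirectly on the new change. Among the measured compounds shown here, no measured compound carries benzyl, so the data set no direction, and no step beyond the scatter is expected in this assay. The expected step is a 1.1-fold lower number from compound 2 to compound 4 (0.04 log units; within the scatter) as a working estimate. For compound 4 the expected value is 30000 nM, with an estimated range from 10000 nM to 90000 nM in this wide band.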

Compound 4, half-maximal inhibitory concentration: 54000 nM
Compound 4: the middle estimate sits 1.8-fold (0.26 log units) below what was measured, within the range that was stated.
By their numbers in this assay, from the lowest: compound 3; then compounds 2, 4 and 1 (each within the scatter of the next, the first and the last beyond it).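

In this assay, benzyl in place of 4-methoxyphenyl on the amide-type nitrogen gives a 1.6-fold higher number from compound 2 to compound 4 (0.21 log units; within the scatter), so this position takes the exchange of the whole group without a step beyond the scatter. Among the compounds shown here, the only earlier step, a 6.6-fold lower number from compound 2 to compound 3 (0.82 log units; beyond the scatter), concerned a single group on the aromatic ring, whereas this one changes what is attached to the nitrogen and removes the methoxy group at the same time. No supporting measurement bears on this result, and it stands here without an explanation.

Open, as far as these compounds go, is whether a longer chain such as 2-phenylethyl, or a chain ending in an amine or a carboxylic acid, would stay in the same band on this nitrogen. Also open, from the compounds shown here alone, is whether a nitro group on the benzyl ring would give a step of the size seen with the aromatic group of compound 3.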